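Cytotoxicity notes: 2-hydroxypropyl to acetyl on nitrogen

This account rests on a few compounds, and the source may have more. Where it says the series, first, only, none or still open, it means among the compounds named here.

Of the compounds shown here, two with a shared core have been read so far in an ADME assay on MT4 cells (Homo sapiens) for cytotoxicity, read by MTT assay, with a stated time of 5 days; on this read-out lower numbers stand for higher toxicity in this test and higher numbers for lower toxicity in this test. Compound 1 (`CCC(C)CN(c1ccnc(Nc2ccc(C#N)cc2)n1)c1c(F)cc(-c2ccc(C#N)cc2)cc1F`) gives > 255000 nM, and this is a limit of the assay, not a number. Within the data shown here, compound 2 (`CC(O)CN(c1ccnc(Nc2ccc(C#N)cc2)n1)c1c(F)cc(-c2ccc(C#N)cc2)cc1F`) gives 9800 nM, the only actual number so far. Among the measured compounds shown here, the one measured step, hydroxy in place of ethyl on a saturated chain carbon, is an at least 26-fold lower number from compound 1 to compound 2 (1.41 log units; beyond the scatter), which is large.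

Compound 3 (`CC(=O)N(c1ccnc(Nc2ccc(C#N)cc2)n1)c1c(F)cc(-c2ccc(C#N)cc2)cc1F`) is next: acetyl in place of 2-hydroxypropyl on a nitrogen on an aromatic ring, (acetyl in place of 2-hydroxypropyl on a nitrogen on an aromatic ring). For the measured compounds named here, the hydroxy leaves with that chain, so the only step bearing on this change is the one in which a hydroxy came in, and compound 2 sits on the lower side of it at an at least 26-fold lower number from compound 1 to compound 2 (1.41 log units; beyond the scatter). That step is a different substitution, so only part of it is expected to reverse. A moderate rise is expected in this assay, with an expected step of a 2.6-fold higher number from compound 2 to compound 3 (0.41 log units; beyond the scatter). The estimate for compound 3 is 25000 nM, with an expected range of 6000 nM to 120000 nM.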

Compound 3, half-maximal cytotoxic concentration: > 268000 nM
Compound 3: no number, only a limit; the forecaster's own chance of this, stated with the estimate: 25%; at least 10-fold (1.03 log units) between middle value and limit.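

In this assay compound 3 gives > 268000 nM, a limit of the assay and not a number. On the nitrogen on an aromatic ring, acetyl in place of 2-hydroxypropyl gives an at least 27-fold higher number from compound 2 to compound 3 (1.43 log units; beyond the scatter), so a measurable cytotoxic concentration in this series is not a feature of the shared core alone but depends on the group at this position. Among these compounds, compound 1 and compound 3 both stand at limits and the step between them cannot be read, which leaves 2-hydroxypropyl as the only one of the three groups on this nitrogen that gives an actual number, while 2-methylbutyl and acetyl, neither of which carries a hydroxy, both end at a limit.

Still open, as far as these compounds go, is whether the hydroxy itself goes with the lower number or whether the rest of the 2-hydroxypropyl chain also plays a part, since the three compounds change more than that one feature at a time. A methoxy or an amine in place of the hydroxy on that same chain would separate these two readings, and a longer chain carrying a terminal hydroxy would show how far the lower number extends.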